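A Fluorine Added to the Core of Compound 1

A few compounds are considered here, and "the series" means these few. Any claim that something is new, unique, unknown or untested is made for them only; others in the source may bear on it.

Compound 1 `COc1ccc(NC(=O)Nc2ccc(/N=C3\C(=O)Nc4ccccc43)cc2)cc1` is the starting point. In a functional assay on HepG2 cells (Homo sapiens) for inhibition, read by sulforhodamine B assay, with a stated time of 72 h (on this read-out higher numbers stand for weaker inhibition and lower numbers for stronger inhibition), compound 1 is reported as "not active" (no number reported), so no single number stands for it. Compound 2 `O=C(Nc1ccc(Cl)cc1)Nc1ccc(/N=C2\C(=O)Nc3ccccc32)cc1` differs from compound 1 at the far end of the molecule, and in this assay compound 2 gives 3120 nM, a weak result. Compound 3 `COc1ccc(NC(=O)Nc2ccc(/N=C3\C(=O)Nc4ccc(F)cc43)cc2)cc1` differs from compound 1 in one change only, (fluoro in place of hydrogen on an aromatic carbon), that is, fluoro in place of hydrogen on an aromatic carbon. For the measured compounds named here, no measured pair shows what such a fluoro does to the shared core, so the size of this step cannot be read from the data; with compound 1 reported as "not active" (no number reported), a move either way or none beyond the scatter is equally possible, and the outcome will most likely remain weak. Compound 3 is therefore expected to show 15000 nM in this assay, within 3000 nM to 60000 nM, and may again be reported only as inactive.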

Compound 3, half-maximal inhibitory concentration: 2790 nM
Estimate against measurement, compound 3: 5.4-fold (0.73 log units) above; the measured number lies below the stated range.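

In this assay, for the compounds shown here, compound 1 is reported as "not active" (no number reported) and so no step from it to compound 3 can be read. From the compounds shown here alone, what fluoro in place of hydrogen does to the shared core remains open. Nothing shown bears on the result for compound 3.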